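Trifluoromethyl on the Phenyl of Compound 3

The source may report more compounds than this note shows. Statements on the series, on what has been measured and on what is new or still open speak of the compounds shown alone.

In a functional assay on HeLa cells (Homo sapiens) for cytotoxicity, read by MTT assay, with a stated time of 72 h (on this read-out lower numbers stand for an effect already at smaller amounts and higher numbers for an effect only at larger amounts of compound), compound 1 `CCS[C@@H]1[C@H](SCC)[C@@H](Cn2cc(-c3ccccc3)nn2)O[C@H]1n1ccc(=O)[nH]c1=O` gives 6590 nM. Compound 2 `CCS[C@@H]1[C@H](SCC)[C@@H](Cn2cc(COC(C)=O)nn2)O[C@H]1n1ccc(=O)[nH]c1=O` carries an acetoxymethyl where compound 1 carries a phenyl. In this assay compound 2 reaches only a limit of the assay, >= 100000 nM. Of the three values shown, compound 2 alone sits at the limit of >= 100000 nM in this assay, at which 1 of the 3 values shown sits. Among the compounds with values here, compound 3 `CCS[C@@H]1[C@H](SCC)[C@@H](Cn2cc(-c3ccccc3)nn2)O[C@H]1n1cc(C)c(=O)[nH]c1=O`, with a methyl on the shared core, gives 1890 nM and so stands lowest of the two numbers known, compound 1 being its nearest neighbour. The two measured steps were an at least 15-fold higher number from compound 1 to compound 2 (1.18 log units; beyond the scatter) and a 3.5-fold lower number from compound 1 to compound 3 (0.54 log units; beyond the scatter). Compound 4 `CCS[C@@H]1[C@H](SCC)[C@@H](Cn2cc(-c3ccccc3C(F)(F)F)nn2)O[C@H]1n1cc(C)c(=O)[nH]c1=O` differs from compound 3 by trifluoromethyl in place of hydrogen on an aromatic carbon; cut one bond further out, the change reads phenyl to 2-(trifluoromethyl)phenyl. Within the data shown here, the large step from compound 1 to compound 2 shows that exchanging the phenyl matters, yet no measured step alters a group on the phenyl itself, so the measured steps bear only loosely on compound 4. The step to compound 4 is therefore expected to be a 1.1-fold higher number from compound 3 to compound 4 (0.02 log units; within the scatter), within the scatter. Compound 4 is estimated at 2000 nM, with a range from 600 nM to 8000 nM.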

Compound 4, half-maximal effective concentration: 54300 nM
For compound 4 the middle estimate is 27-fold (1.43 log units) below the measured one; measured number above the stated range.
By their numbers in this assay, from the lowest: compound 3; then compound 1; then compound 4. At a limit, above all of these: compound 2.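

In this assay, the phenyl proves sensitive even to a single added group: trifluoromethyl in place of hydrogen brings a 29-fold higher number from compound 3 to compound 4 (1.46 log units; beyond the scatter). Until now, only exchanging the whole phenyl had given a large step, whereas here the phenyl stays and one change on an aromatic carbon, ortho to a large group, is enough to give a large step. Nothing measured among these compounds accounts for this rise.

The compounds shown leave open whether a fluorine, a methoxy or an amine on that same carbon would give a step of similar size, and whether trifluoromethyl on another carbon of the phenyl would. Going by these compounds, it also remains open whether the same change would give a similar step on compound 1, which lacks the methyl of compound 3.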